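A few compounds are considered here, and "the series" means these few. Any claim that something is new, unique, unknown or untested is made for them only; others in the source may bear on it.

Measured so far in a functional assay on HCT-116 cells (Homo sapiens) for cytotoxicity, read by MTT assay, with a stated time of 48 h; a higher number here means a weaker inhibitor, a lower number a stronger inhibitor:
compound 1 `Cc1nc2c3ccccc3ccc2c2nc3c(ccc4ccccc43)c(-c3nccnc3N)c12` gives 3560 nM
compound 2 `Cc1nc2c3ccccc3ccc2c2nc3c(ccc4ccccc43)c(-c3ccc(O)cc3)c12` gives 3190 nM
compound 3 `Cc1nc2c3ccccc3ccc2c2nc3c(ccc4ccccc43)c(-c3cc(O)nc4ccccc34)c12` gives 4630 nM

Compound 3 carries the largest of these three numbers, yet both a 1.3-fold higher number from compound 1 to compound 3 (0.11 log units; within the scatter) and a 1.5-fold higher number from compound 2 to compound 3 (0.16 log units; within the scatter) sit within the scatter, so the three compounds cannot be told apart on these data. Compound 4 `Cc1nc2c3ccccc3ccc2c2nc3c(ccc4ccccc43)c(-c3ccccc3)c12` differs from compound 3 in one place: phenyl in place of 2-hydroxyquinolin-4-yl on an aromatic carbon. The step that bears on this is the one replacing a hydroxyphenyl with the hydroxyquinolinyl group, a 1.5-fold higher number from compound 2 to compound 3 (0.16 log units; within the scatter), which stayed within the scatter, as did a 1.3-fold higher number from compound 1 to compound 3 (0.11 log units; within the scatter). For the measured compounds named here, no measured step removes every donor and acceptor from this position, so the expectation is simply no step beyond the scatter in this assay. Compound 4 is therefore estimated at 3800 nM, with a range from 1800 nM to 8500 nM, meaning an expected step of a 1.2-fold lower number from compound 3 to compound 4 (0.09 log units; within the scatter).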

Compound 4, half-maximal inhibitory concentration: > 80000 nM
Compound 4: only a limit was reported; the forecaster's own chance of this, stated with the estimate: 10%; at least 21-fold (1.32 log units) between middle value and limit.
By their numbers in this assay, from the lowest: compounds 2, 1 and 3 (each within the scatter of the next). At a limit, above all of these: compound 4.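

In this assay, compound 4 gives only a limit, not a number: the limit of > 80000 nM in this assay, at which 1 of the 4 values shown sits.

The three earlier groups at this position could not be told apart, so the position seemed to tolerate change, but phenyl gives an at least 17-fold higher number from compound 3 to compound 4 (1.23 log units; beyond the scatter) and an at least 22-fold higher number from compound 1 to compound 4 (1.35 log units; beyond the scatter). Losing the hydroxy of the 4-hydroxyphenyl group alone is enough for an at least 25-fold higher number from compound 2 to compound 4 (1.39 log units; beyond the scatter), so this one small change separates active from inactive here.

Still open, on these data alone, is whether the hydroxy itself is what counts. A methoxy group or a carboxylic acid on the phenyl ring in its place would help to show this.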